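Swapping 4-cyanophenoxy for 4-cyanophenyl in a urea series

This account rests on a few compounds, and the source may have more. Where it says the series, first, only, none or still open, it means among the compounds named here.

Three ureas on a shared core have been tested in an ADME assay on cells (Peritoneal macrophage cell, Mus musculus) for cytotoxicity, read by fluorescence and resazurin assay, with a stated time of 3 days; on this read-out lower numbers stand for higher toxicity in this test and higher numbers for lower toxicity in this test. Compound 1 `O=C(Nc1cc(-c2ccccn2)n[nH]1)N1CCC(Oc2ccccn2)CC1` reaches only the limit of this test, giving > 64000 nM. Compound 2 `O=C(Nc1cc(-c2ccccn2)n[nH]1)N1CCC(c2ccc(F)cc2)CC1` likewise gives only a limit, > 64000 nM. Compound 3 `N#Cc1ccc(OC2CCN(C(=O)Nc3cc(-c4ccccn4)n[nH]3)CC2)cc1` also gives only a limit, > 64000 nM. Because all three sit at the limit of > 64000 nM in this assay, at which 3 of the 3 values shown sit, the steps a step that the two limits leave unreadable from compound 1 to compound 2, a step that the two limits leave unreadable from compound 1 to compound 3 and a step that the two limits leave unreadable from compound 2 to compound 3 cannot be sized. Compound 4 `N#Cc1ccc(C2CCN(C(=O)Nc3cc(-c4ccccn4)n[nH]3)CC2)cc1` differs from compound 3 by 4-cyanophenyl in place of 4-cyanophenoxy on a saturated ring carbon. For the measured compounds named here, no measured step sizes this change, and every value so far is a limit. Compound 4 is therefore expected to stay at the limit as well, around 64000 nM (range 20000 nM to 200000 nM). The expected step of a number no higher from compound 3 to compound 4 (the limit leaves the size open) is estimated to be none beyond the scatter.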

Compound 4, half-maximal cytotoxic concentration: > 64000 nM
Compound 4: no number, only a limit; the forecaster's own chance of this, stated with the estimate: 80%; the middle value lies on the limit itself.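

Compound 4 also gives only a limit, so the steps to it from compound 1, compound 2 and compound 3 cannot be read: the limit of > 64000 nM in this assay, at which 4 of the 4 values shown sit.

In this assay, going by these compounds, the concentration at which any of these four compounds becomes toxic to the cells stays open.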